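Substituent at the benzyl ring: from hydrogen to pyrrolidinyloxy

This account rests on a few compounds, and the source may have more. Where it says the series, first, only, none or still open, it means among the compounds named here.

Measured compounds:
compound 1 `Nc1cc(Cc2ccn(Cc3cccc(-c4ccccc4)c3)n2)c2nn[nH]c2n1`, 55 nM
compound 2 `Nc1cc(Cc2ccn(Cc3cccc(Cc4ccccc4)c3)n2)c2nn[nH]c2n1`, 39 nM
compound 3 `Nc1cc(Cc2ccn(Cc3ccccc3)n2)c2nn[nH]c2n1`, 120 nM

In an assay on isolated protein for inhibition of Myeloperoxidase (Homo sapiens), with a stated time of 10 min (a lower number here means a stronger inhibitor, a higher number a weaker inhibitor), compound 3 gives the highest number of the three. Its nearest neighbour is compound 1, and the step of a 2.2-fold higher number from compound 1 to compound 3 (0.34 log units; beyond the scatter) is modest but beyond the scatter; the step of a 3.1-fold higher number from compound 2 to compound 3 (0.49 log units; beyond the scatter) is likewise modest and beyond the scatter. The pair compound 1 and compound 2 lies within the scatter a 1.4-fold lower number from compound 1 to compound 2 (0.15 log units; within the scatter).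

Compound 4 `Nc1cc(Cc2ccn(Cc3cccc(O[C@H]4CCNC4)c3)n2)c2nn[nH]c2n1` differs from compound 3 by the change ((pyrrolidin-3-yl)oxy in place of hydrogen on an aromatic carbon). Both measured steps bear on it in that each replaces a hydrogen at the same place with a larger group, and each gave a modest lower number. The entering group here is not an aromatic ring but a five-membered non-aromatic ring with one hetero atom, one donor and two acceptors, so the measured steps are only a loose guide. A modest lower number is expected, with a wide range. The expected step is a 2.2-fold lower number from compound 3 to compound 4 (0.34 log units; beyond the scatter). Compound 4 is therefore estimated at 55 nM, in the range 20 nM to 160 nM in this assay.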

Compound 4, half-maximal inhibitory concentration: 46 nM
Compound 4: the middle estimate sits 1.2-fold (0.08 log units) above what was measured; the range from low to high includes it.
By their numbers in this assay, from the lowest: compounds 2, 4 and 1 (each within the scatter of the next); then compound 3.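

The step over hydrogen does not depend on an aromatic entering group: in this assay, (pyrrolidin-3-yl)oxy gives a 2.6-fold lower number from compound 3 to compound 4 (0.42 log units; beyond the scatter), a modest step beyond the scatter, as benzyl and phenyl did at this place. Against those two groups, a 1.2-fold higher number from compound 2 to compound 4 (0.07 log units; within the scatter) and a 1.2-fold lower number from compound 1 to compound 4 (0.08 log units; within the scatter) both lie within the scatter, so the three substituents cannot be told apart here, despite the non-aromatic ring and hetero atoms of the new group. No measurement at hand accounts for this equivalence.

The compounds shown leave open which part of the entering group carries the step: the ring nitrogen, the ether oxygen or size alone. Also open, going by these compounds, is how a cyclopentyloxy group, a methoxy group or a carboxylic acid would compare at this place, and what the opposite configuration at the stereocentre would give.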